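Swapping a Branched Ether for a Cyclobutyl Ether

The source may hold more compounds than are shown below. What is called first, only, known or untested is meant among the compounds shown, and "the series" means these compounds.

Of the compounds shown here, two with a shared core have been tested, and a third awaits its number. Within the data shown here, in an assay on cells with melanin-concentrating hormone receptor 1 (Homo sapiens) as the target, read by radioligand binding (on this read-out lower numbers stand for stronger inhibition and higher numbers for weaker inhibition), compound 1 `CC(C)C(C)Oc1cccc2ccc(N)nc12` gives 199 nM, and this is the only plain number among the results so far. Compound 2 `CC(CC(C)(C)C)Oc1cccc2ccc(N(C)C)nc12` sits at the limit of > 2000 nM in this assay, at which 1 of the 2 values shown sits, so its result of > 2000 nM in this assay is a limit rather than a number. Among the measured compounds shown here, compound 2 differs from compound 1 in two places at once, so no single step between measured compounds can be read from this pair.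

Compound 3 `Nc1ccc2cccc(OC3CCC3)c2n1` is built from compound 1 by one change: cyclobutyl in place of 1,2-dimethylpropyl on an oxygen on an aromatic ring. The group that leaves and the group that enters are both small, uncharged hydrocarbons without donors or acceptors, so the change is modest in size. For the measured compounds named here, with no measured step to lean on, the expected step of a 1.5-fold higher number from compound 1 to compound 3 (0.18 log units; within the scatter) is small, at most a slight weakening and possibly none beyond the scatter. Compound 3 is therefore estimated at 300 nM, with a likely range from 100 nM to 1000 nM.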

Compound 3, half-maximal inhibitory concentration: > 2000 nM
Compound 3: a limit, no number (the forecaster's own chance of this, stated with the estimate: 10%); at least 6.6-fold (0.82 log units) between middle value and limit.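

Among these compounds, this pair gives the first single change that can be read: with the rest of compound 1 kept, cyclobutyl in place of 1,2-dimethylpropyl on an oxygen on an aromatic ring gives an at least 10-fold higher number from compound 1 to compound 3 (1.00 log units; beyond the scatter) in this assay. The group at this place therefore matters for the read-out, and two hydrocarbon groups cannot be treated as interchangeable here, even though neither carries a hydrogen-bond donor, a hydrogen-bond acceptor or a net charge. The result for compound 3 is a limit and not a number, so the step has a known lower bound but no known full size, and this limit is now shared by most of the small set: the limit of > 2000 nM in this assay, at which 2 of the 3 values shown sit.

The compounds shown leave open whether the weaker result goes with the ring itself, with the branched chain that left, or with the change in the number of carbons. A cyclopentyl group or a straight butyl chain on the same oxygen would help separate these possibilities, and a number below the limit would be needed to measure how large such effects are.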